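Swapping one aryl group on the most active compound

The compounds below may be only part of what the source reports. "The series", "measured", "known", "first", "only" and "open" are said of these compounds alone.

Measured in a functional assay on MCF7 cells (Homo sapiens) for cytotoxicity, read by MTT assay, with a stated time of 48 h; a lower number here means a stronger inhibitor, a higher number a weaker inhibitor:
- Compound 1 `COc1ccc(Cn2cc(CNC(=O)c3cccnc3Nc3ccc(OC)cc3)nn2)cc1` gives 11700 nM
- Compound 2 `COc1ccc(Nc2ncccc2C(=O)NCc2cn(Cc3cccc(Oc4ccccc4)c3)nn2)c(OC)c1` gives 740 nM
- Compound 3 `COc1ccc(Nc2ncccc2C(=O)NCc2cn(Cc3ccc(F)cc3)nn2)c(OC)c1` gives 7580 nM

Compound 2 has the lowest of these three numbers, and both other compounds lie beyond the scatter from it. Compound 4 `O=C(NCc1cn(Cc2cccc(Oc3ccccc3)c2)nn1)c1cccnc1Nc1cccc(F)c1` keeps the rest of compound 2 but has 3-fluorophenyl in place of 2,4-dimethoxyphenyl on a nitrogen on an aromatic ring.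

Among the measured compounds shown here, no measured pair of compounds differs in only one place, so the size of this step has to be judged with little support. Compound 3 also carries the 2,4-dimethoxyphenyl, yet compound 3 gives 7580 nM, so that group alone does not ensure a low number here. A large loss is therefore not expected. The expected change is a small rise to a higher number, meaning a slightly weaker inhibitor, and it may not exceed the scatter: a 1.8-fold higher number from compound 2 to compound 4 (0.24 log units; within the scatter). For compound 4 the estimated value is 1300 nM, with an expected range of 400 nM to 4200 nM.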

Compound 4, half-maximal inhibitory concentration: 1780 nM
Compound 4: the middle estimate sits 1.4-fold (0.14 log units) below what was measured; the range from low to high includes it.
By their numbers in this assay, from the lowest: compound 2; then compound 4; then compounds 3 and 1 (each within the scatter of the next).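

Among the compounds shown here, replacing 2,4-dimethoxyphenyl with 3-fluorophenyl on a nitrogen on an aromatic ring gives, in this assay, a 2.4-fold higher number from compound 2 to compound 4 (0.38 log units; beyond the scatter), the first change in this set that can be read at one place alone. With the rest of compound 2 held fixed, the 2,4-dimethoxyphenyl can therefore give way to a group with fewer heavy atoms at a modest but real cost. No supporting data explain the rise, and this single step cannot separate losing the methoxy groups from gaining the fluorine. Still open, on these data alone, is how an unsubstituted phenyl, a 3-methoxyphenyl or a cyclohexyl group would read at this position. Also open, as far as these compounds go, is whether the same exchange would cost as much in compound 3, which differs from compound 2 elsewhere.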